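The source may report more compounds than this note shows. Statements on the series, on what has been measured and on what is new or still open speak of the compounds shown alone.

In a functional assay on NCI-H460 cells (Homo sapiens) for inhibition, read by MTT assay, with a stated time of 24 h, tested at 10 ug/mL (on this read-out higher numbers stand for more inhibition of growth at the one concentration tested and lower numbers for less inhibition of growth), compound 3 `COc1ccc(NC(=O)CCCCC(S)CCS)cc1` gives 1.43% and lies within the scatter of compound 2 `O=C(CCCCC(S)CCS)Nc1ccc([N+](=O)[O-])c(C(F)(F)F)c1` at 0.97% in these notes. Compound 1 `O=C(CCCCC(S)CCS)Nc1ccc(Cl)cc1` gives 22% and stands beyond the scatter from compound 3 on the same read-out.

The next structure is compound 4 `O=C(CCCCC(S)CCS)Nc1ccc([N+](=O)[O-])cc1` and the change is nitro in place of methoxy on an aromatic carbon in full: nitro in place of methoxy on an aromatic carbon, para to a large group.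

For the measured compounds named here, one measured step bears on this directly: a number 20.6 percentage points lower from compound 1 to compound 3 (beyond the scatter) when methoxy replaces chloro. It is a modest step, beyond the scatter, and it shows that a swap of this kind can alter the reading, though it does not involve nitro. Going by the values given here, no measured step brings in nitro alone. The nearest evidence is compound 2, which carries nitro together with trifluoromethyl and gives 0.97% in this assay as its reading. On that basis, no step beyond the scatter is expected in this assay for this change, with some room left upward.

The estimated step is a number 3.6 percentage points higher from compound 3 to compound 4 (within the scatter) as the working expectation. For compound 4 the expected value is 5% with an estimated range from 0% to 20% in this assay.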

Compound 4, percent growth inhibition at one concentration: 13.4%
Compound 4: middle estimate off by 8.4 percentage points, on the low side; measured number inside the range.
By their numbers in this assay, from the lowest: compounds 2 and 3 (each within the scatter of the next); then compounds 4 and 1 (each within the scatter of the next).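

Nitro in place of methoxy on an aromatic carbon, para to a large group, gives a number 12 percentage points higher from compound 3 to compound 4 (beyond the scatter) in this assay, so the low reading of compound 3 does not hold for every group at this place. Nitro in place of chloro gives a number 8.6 percentage points lower from compound 1 to compound 4 (within the scatter), so these two groups are not told apart here, while methoxy stands beyond the scatter from both of them. Hydrogen in place of trifluoromethyl gives a number 12.4 percentage points higher from compound 2 to compound 4 (beyond the scatter), which shows for the first time what nitro does without trifluoromethyl on the ring: the low reading of compound 2 is not carried by nitro alone, and it goes with the added trifluoromethyl.

Still open, from the compounds shown here alone, is how an amine or a carboxylic acid at this place would read, and whether the ring without any such group would fall with compound 3 or with compound 1 and compound 4. Nothing on hand gives a cause for any of these steps.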